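Three Styryl Compounds and One Added Methoxy

This account rests on a few compounds, and the source may have more. Where it says the series, first, only, none or still open, it means among the compounds named here.

In a functional assay on U-251 cells (Homo sapiens) for inhibition, read by sulforhodamine B assay, with a stated time of 48 h (on this read-out higher numbers stand for weaker inhibition of growth and lower numbers for stronger inhibition of growth), compound 1 (`CC1(/C=C/c2ccccc2)C=CC(=O)O1`) gives 89800 nM, compound 2 (`CC1(/C=C/c2ccc(F)cc2)C=CC(=O)O1`) gives 60800 nM and compound 3 (`COc1ccc(/C=C/C2(C)C=CC(=O)O2)c(OC)c1`) gives 62800 nM. Compound 3 thus stands within the scatter of both other compounds, and the three values form a single group. Compound 4 (`COc1cc(OC)c(OC)cc1/C=C/C1(C)C=CC(=O)O1`) differs from compound 3 by methoxy in place of hydrogen on an aromatic carbon. That is, it has methoxy in place of hydrogen on an aromatic carbon. Among the compounds with values here, no measured step shows this exact change. The nearest evidence is another single replacement on an aromatic carbon, fluoro in place of hydrogen, which is a 1.5-fold lower number from compound 1 to compound 2 (0.17 log units; within the scatter). That step bears on the new change only loosely, yet it gives no reason to expect a large shift. No step beyond the scatter is therefore expected in this assay, and no direction can be favoured. The expected step is a 1.0-fold lower number from compound 3 to compound 4 (0.01 log units; within the scatter). For compound 4 the estimated value is 62000 nM, within an expected range of 35000 nM to 100000 nM.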

Compound 4, concentration for total growth inhibition: 160000 nM
Compound 4: middle estimate off by 2.6-fold (0.41 log units), on the low side; measured number outside the range, above it.
By their numbers in this assay, from the lowest: compounds 2, 3, 1 and 4 (each within the scatter of the next, the first and the last beyond it).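

In this assay methoxy in place of hydrogen, on an aromatic carbon ortho to a methoxy group, meta to a group of 9 heavy atoms and para to a methoxy group, gives a 2.5-fold higher number from compound 3 to compound 4 (0.41 log units; beyond the scatter) and so goes with weaker inhibition of growth. Within the data shown here, it is the first single replacement in this set with a step beyond the scatter, whereas the one earlier step, fluoro in place of hydrogen, was a 1.5-fold lower number from compound 1 to compound 2 (0.17 log units; within the scatter) in another pair. Nothing measured here accounts for why this added methoxy weakens inhibition of growth.

On these data alone, whether a smaller group such as fluoro or hydroxy, or an amine, would give a step of this size on the same aromatic carbon remains open. Also open is whether the step depends on the two methoxy groups already on the ring, as no compound shown carries the added methoxy without them.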